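A few compounds are considered here, and "the series" means these few. Any claim that something is new, unique, unknown or untested is made for them only; others in the source may bear on it.

Measured so far in an assay for binding affinity to dual specificity mitogen-activated protein kinase kinase 4 (Homo sapiens), read by KINOMEscan, tested at 100 nM; on this read-out higher numbers stand for a weaker effect at the one concentration tested and lower numbers for a stronger effect:
- compound 1 `CCCS(=O)(=O)Nc1ccc(F)c(C(=O)c2n[nH]c3ncc(-c4cccc(Cl)c4)cc23)c1F` gives 40%
- compound 2 `CCCS(=O)(=O)Nc1ccc(F)c(C(=O)c2n[nH]c3ncc(-c4ccc(O)cc4)cc23)c1F` gives 0.75%
- compound 3 `CCCS(=O)(=O)Nc1ccc(F)c(C(=O)c2n[nH]c3ncc(-c4ccc(S(C)(=O)=O)cc4)cc23)c1F` gives 1.5%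

Compound 2 stands lowest of the three, but compound 3 sits within the scatter of it, a number 0.8 percentage points higher from compound 2 to compound 3 (within the scatter); only compound 1 is clearly apart, a number 39.3 percentage points lower from compound 1 to compound 2 (beyond the scatter).

Compound 4 `CCCS(=O)(=O)Nc1ccc(F)c(C(=O)c2n[nH]c3ncc(-c4ccc(S(=O)(=O)NCC)cc4)cc23)c1F` differs from compound 2 by ethylsulfamoyl in place of hydroxy on an aromatic carbon. Within the data shown here, the step that bears on it most is the one from compound 2 to compound 3, which was within the scatter despite a change at the same carbon; the large steps from compound 1 to compound 2 and from compound 1 to compound 3 both concern a different change. No step beyond the scatter is therefore expected in this assay for compound 4, expected a number 1.3 percentage points higher from compound 2 to compound 4 (within the scatter).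

Estimate for compound 4: 2%, range 0.3% to 10%.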

Compound 4, a percentage reported as activity, at one concentration (the size of the read-out at that concentration, not a potency): 3%
Beside the measured number, compound 4's estimate is 1 percentage points below it; measured number inside the range.
By their numbers in this assay, from the lowest: compounds 2, 3 and 4 (each within the scatter of the next); then compound 1.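

In this assay this aromatic carbon accepts the far larger ethylsulfamoyl group in place of hydroxy with no step beyond the scatter: a number 2.3 percentage points higher from compound 2 to compound 4 (within the scatter). Ethylamino in place of methyl on the sulfonyl sulfur also stays within the scatter: a number 1.5 percentage points higher from compound 3 to compound 4 (within the scatter). The 4-(ethylsulfamoyl)phenyl group therefore keeps the large separation from the 3-chlorophenyl group: a number 37 percentage points lower from compound 1 to compound 4 (beyond the scatter). No supporting data explain these results. Open, as far as these compounds go, is whether a carboxylic acid or an amine on this carbon, or a longer chain on the sulfonamide nitrogen, would hold the read-out in this range.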